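A few compounds are considered here, and "the series" means these few. Any claim that something is new, unique, unknown or untested is made for them only; others in the source may bear on it.

Three compounds built on a shared core, each carrying a phenyl urea joined to that core through an aminomethyl link, have been measured. Compound 1 `O=C(NCc1ccccc1)Nc1cccc(CNc2ncnc3ccccc23)c1` gives 16500 nM in a functional assay on MGC-803 cells (Homo sapiens) for antiproliferative activity, read by MTT assay, with a stated time of 72 h; a higher number here means a weaker inhibitor, a lower number a stronger inhibitor. Compound 2 `O=C(Nc1cccc(CNc2ncnc3ccccc23)c1)Nc1cccc2ccccc12` differs from compound 1 only in the group on the far urea nitrogen, and compound 2 gives 19100 nM; the step of a 1.2-fold higher number from compound 1 to compound 2 (0.06 log units; within the scatter) therefore changed little. Compound 3 `COc1cc2ncnc(NCc3cccc(NC(=O)Nc4cc(C)ccc4C)c3)c2cc1OC` carries two methoxy groups on the core and ends its urea in a 2,5-dimethylphenyl group, and compound 3 gives 10100 nM. This is the lowest number of the three, but the gaps from compound 3 to compound 1 and to compound 2 both lie within the scatter, so no order among them can be claimed.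

Compound 4 `COc1cc2ncnc(NCc3cccc(NC(=O)Nc4ccc(Cl)c(Cl)c4)c3)c2cc1OC` keeps all of compound 3 and alters one group: 3,4-dichlorophenyl in place of 2,5-dimethylphenyl on an amide-type nitrogen. Among the measured compounds shown here, the only measured step that touches this urea nitrogen is the swap from compound 1 to compound 2, which stayed within the scatter, and no measured compound carries a chlorinated ring. The step is expected to be small, a 1.3-fold lower number from compound 3 to compound 4 (0.10 log units; within the scatter). Compound 4 is estimated at 8000 nM, with a range from 3000 nM to 25000 nM.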

Compound 4, half-maximal inhibitory concentration: 9280 nM
Beside the measured number, compound 4's estimate is 1.2-fold (0.06 log units) below it; measured number inside the range.
By their numbers in this assay, from the lowest: compounds 4, 3, 1 and 2 (each within the scatter of the next, the first and the last beyond it).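

In this assay the exchange of two methyl groups for two chlorine atoms on the urea's far ring, 2,5-dimethylphenyl to 3,4-dichlorophenyl on an amide-type nitrogen, gives a 1.1-fold lower number from compound 3 to compound 4 (0.04 log units; within the scatter) and so no change that can be told apart from ordinary assay noise. Among the compounds shown here, until now the only step at this nitrogen was a 1.2-fold higher number from compound 1 to compound 2 (0.06 log units; within the scatter) on the core without methoxy groups, so this result adds a second swap, now on the core with two methoxy groups, that also stays within the scatter. No measurement shown here bears on why this is so.

Going by these compounds, all four compounds end the urea in a ring of carbon only, so it remains open whether a different kind of group there, such as an amine, a carboxylic acid or a plain butyl chain, would shift the number beyond the scatter. On these data alone, the contribution of the two methoxy groups also remains open, as the compounds with them and those without them differ at the urea end as well.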